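The source may report more compounds than this note shows. Statements on the series, on what has been measured and on what is new or still open speak of the compounds shown alone.

Going by the values given here, compound 1, with the structure `O=S1(=O)N=C(NCC2CCCCC2)Nc2ncccc21`, is the only member of this small set that gives a number in a functional assay (ileum) for inhibition, with Cavia porcellus as the target; on this read-out higher numbers stand for an effect only at larger amounts of compound and lower numbers for an effect already at smaller amounts: compound 1 gives 145 uM. Compound 2, `C[C@@H](NC1=NS(=O)(=O)c2cccnc2N1)C1CCCCC1`, carries a methyl in place of hydrogen on a saturated chain carbon bound to an amine nitrogen and a saturated ring carbon. In this assay compound 2 reaches only the assay limit, > 300 uM. That change made an at least 2.0-fold higher number from compound 1 to compound 2 (0.31 log units; beyond the scatter). Compound 3, `CC(C)C(C)NC1=NS(=O)(=O)c2cc(Cl)cnc2N1`, rests on a different core; the difference between the two cores is not broken down here. In this assay compound 3 also gives only a limit, > 300 uM. Compound 4, `CC(NC1=NS(=O)(=O)c2cc(Cl)cnc2N1)C(C)(C)C`, is not yet measured; it differs from compound 3 by a methyl in place of hydrogen on a saturated chain carbon bound to three saturated chain carbons, the same kind of change as before, but now the place is bound to three saturated chain carbons rather than to an amine nitrogen and a saturated ring carbon. Given (the limit of > 300 uM in this assay, at which 2 of the 3 values shown sit), the step is expected to be about a step that the limit leaves unreadable from compound 3 to compound 4, alongside the earlier at least 2.0-fold higher number from compound 1 to compound 2 (0.31 log units; beyond the scatter). Compound 4 is therefore estimated at 600 uM in this assay, most likely again only a limit.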

Compound 4, concentration for half-maximal effect: > 300 uM
Compound 4 ended at the assay's limit (the forecaster's own chance of this, stated with the estimate: 80%); the middle value does not contradict the limit.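

No step can be read between compound 3 and compound 4 in this assay, because both compounds give only a limit, not a number: the limit of > 300 uM in this assay, at which 3 of the 4 values shown sit. The compounds shown leave open whether the change from isopropyl to tert-butyl alters the effect at all, and what numbers compound 3 and compound 4 would give.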